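The source may report more compounds than this note shows. Statements on the series, on what has been measured and on what is new or still open speak of the compounds shown alone.

Compound 1, `COc1cc(-c2cc(/C=C/C(=O)c3ccc(N)cc3)[nH]n2)cc(OC)c1OC`, and compound 2, `COc1ccc(-c2cc(/C=C/C(=O)c3ccc(OC)c(OC)c3)[nH]n2)cc1`, were both examined in a functional assay on KM12 cells (Homo sapiens) for inhibition, read by sulforhodamine B assay, with a stated time of 48 h; a lower number here means a stronger inhibitor of growth, a higher number a weaker inhibitor of growth. In this assay compound 1 gives 2880 nM, and compound 2 gives 3110 nM. Of the two numbers, compound 1 has the lower one, but the gap to compound 2 lies within the usual scatter of repeated runs, so the two values are best read as indistinguishable on this evidence. The next compound to consider is compound 3, `COc1cc(-c2cc(/C=C/C(=O)c3ccc(Cl)c(Cl)c3)[nH]n2)cc(OC)c1OC`, which differs from compound 1 in a single place: 3,4-dichlorophenyl in place of 4-aminophenyl on a carbonyl carbon. Within the data shown here, no measured pair makes this particular change, so there is nothing to calibrate it against. The change from compound 1 to compound 3 is expected to shift the number only modestly, a step of about a 1.4-fold higher number from compound 1 to compound 3 (0.14 log units; within the scatter) towards a slightly weaker inhibition of growth, though a result within the scatter would not surprise. Compound 3 is therefore estimated at 4000 nM in this assay, most likely somewhere between 1500 nM and 12000 nM.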

Compound 3, concentration for total growth inhibition: > 100000 nM
Compound 3 ended at the assay's limit; the forecaster's own chance of this, stated with the estimate: 10%; middle value at least 25-fold (1.39 log units) from the limit.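

At this position, on a carbonyl carbon, 3,4-dichlorophenyl in place of 4-aminophenyl gives an at least 34-fold higher number from compound 1 to compound 3 (1.54 log units; beyond the scatter) in this assay, so the core of compound 1 does not tolerate every aryl group here. Among these compounds, compound 1 and compound 2 differ in more than one place, so only this step isolates the group on the carbonyl carbon. In this assay compound 3 gives > 100000 nM, which is a limit of the assay and not a number, so the true size of the step stays unknown: the limit of > 100000 nM in this assay, at which 1 of the 3 values shown sits.

The compounds shown do not tell whether the step follows from losing the amine or from gaining the two chlorine atoms. A plain phenyl, or a phenyl carrying a hydroxyl or a single chlorine, on the same carbonyl carbon would begin to separate these two parts of the change.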